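A few compounds are considered here, and "the series" means these few. Any claim that something is new, unique, unknown or untested is made for them only; others in the source may bear on it.

Working notes on the series in an ADME assay on MT4 cells (Homo sapiens) for cytotoxicity, read by MTT assay, with a stated time of 4 days; a lower number here means that less compound is tolerated, a higher number that more compound is tolerated. Compound 1 `C/C(=N\NC(=O)COc1cccc2ccccc12)c1ccc(C#N)cc1Br` gives 12.1 ug/mL, compound 2 `O=C(COc1cccc2ccccc12)N/N=C/c1ccccc1Br` gives 11.4 ug/mL, and compound 3 `COc1ccc(OC)c(/C=N/NC(=O)COc2cccc3ccccc23)c1` gives 19.3 ug/mL. Compound 2 stands within the scatter of both other compounds, so the three values show no order. Compound 4 `CSc1ccc(/C=N/NC(=O)COc2cccc3ccccc23)cc1` is not yet measured. It differs from compound 2 as follows: 4-(methylsulfanyl)phenyl in place of 2-bromophenyl on a carbon with a double bond to nitrogen. This places 4-(methylsulfanyl)phenyl in place of 2-bromophenyl on a carbon with a double bond to nitrogen. Within the data shown here, no single-place step between measured compounds is available as a guide. Compound 3, which carries no bromine, at 19.3 ug/mL still lies within the scatter of compound 2, so no step beyond the scatter is expected in this assay, in either direction. The expected step is a 1.3-fold higher number from compound 2 to compound 4 (0.12 log units; within the scatter). For compound 4 the estimated value is 15 ug/mL, with an expected range of 7 ug/mL to 30 ug/mL.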

Compound 4, half-maximal cytotoxic concentration: 68.3 ug/mL
For compound 4 the middle estimate is 4.6-fold (0.66 log units) below the measured one; the whole stated range lies below it.
By their numbers in this assay, from the lowest: compounds 2, 1 and 3 (each within the scatter of the next); then compound 4.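

In this assay, the group on a carbon with a double bond to nitrogen now shows a step beyond the scatter: 4-(methylsulfanyl)phenyl in place of 2-bromophenyl gives a 6.0-fold higher number from compound 2 to compound 4 (0.78 log units; beyond the scatter). Among these compounds, the earlier compounds showed no step beyond the scatter, so this is the first sign that the number can shift markedly with this change. No available measurement bears on the cause of this step.

Going by these compounds, whether the step goes with the 2-bromophenyl leaving or the 4-(methylsulfanyl)phenyl entering remains open. On these data alone, how a plain phenyl or a 4-aminophenyl would stand at this place also remains open.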